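Swapping the sulfonyl imine of compound 1 for a thiosemicarbazone

The source may report more compounds than this note shows. Statements on the series, on what has been measured and on what is new or still open speak of the compounds shown alone.

Measured compounds:
compound 1 `O=C1/C(=N\S(=O)(=O)C(F)(F)F)NCCN1Cc1ccc(Cl)nc1` with 593 nM
compound 2 `CN1CCN(Cc2ccc(Cl)nc2)/C(=N/C#N)C1=O` with 6 nM

In an assay on membranes from Head for displacement of a labelled ligand from Nicotinic acetylcholine receptor alpha 5 subunit (Musca domestica), read by scintillation counting, with a stated time of 1 h (on this read-out lower numbers stand for stronger inhibition and higher numbers for weaker inhibition), compound 1 gives 593 nM, the higher of the two numbers measured. Among the compounds with values here, compound 2 gives 6 nM in this assay; the two values stand far apart, well beyond the usual scatter, and no single-point step between them is recorded, so only the two values themselves can be compared.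

The step to the unmeasured compound 3 `NC(=S)N/N=C1/NCCN(Cc2ccc(Cl)nc2)C1=O` is a group of 4 heavy atoms (1 carbon, 2 nitrogen, 1 sulfur; no ring) in place of a group of 7 heavy atoms (1 carbon, 2 oxygen, 3 fluorine, 1 sulfur; no ring), on a double-bonded nitrogen. The (trifluoromethyl)sulfonyl group leaves and a smaller group carrying two hydrogen-bond donors enters on the double-bonded nitrogen of the shared core. Within the data shown here, no measured pair shows this kind of change, so its effect is uncertain. The author expects compound 3 to land near compound 1 in this assay, with a step of a 1.7-fold lower number from compound 1 to compound 3 (0.23 log units; within the scatter), a move that is estimated to be no larger than the scatter in either direction. The estimate for compound 3 in this assay is 350 nM, within a range from 50 nM to 2500 nM.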

Compound 3, inhibition constant: 3920 nM
The estimate for compound 3 lay 11-fold (1.05 log units) below the measured number; the measured number lies above the stated range.
By their numbers in this assay, from the lowest: compound 2; then compound 1; then compound 3.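

In this assay, the group on the double-bonded nitrogen proves to matter: putting the thiosemicarbazone group in place of the (trifluoromethyl)sulfonyl group gives a 6.6-fold higher number from compound 1 to compound 3 (0.82 log units; beyond the scatter). Within the data shown here, this is the first change at a single place on the shared core, so it shows that the number responds to what this nitrogen carries, which compound 1 and compound 2 could not show, as they differ in more than one place. No measurement at hand accounts for this rise in the number.

A single step cannot separate the departure of the (trifluoromethyl)sulfonyl group from the arrival of the entering group with its hydrogen-bond donors, nor can it tell whether the sulfur of the entering group plays any part in the result. A semicarbazone, with oxygen in place of that sulfur, and a methanesulfonyl group on the same nitrogen would each change only one of these features, so the compounds shown leave open which feature of either group governs the number in this assay.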